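Removing the nitro group from an inactive indanone analogue

This account rests on a few compounds, and the source may have more. Where it says the series, first, only, none or still open, it means among the compounds named here.

Of the compounds shown here, three sharing one core have been tested in a functional assay on PC-3 cells (Homo sapiens) for antiproliferative activity, read by MTT assay, with a stated time of 48 h; a higher number here means a weaker inhibitor of growth, a lower number a stronger inhibitor of growth. Compound 1 `COc1ccc(/C=C2\Cc3c(cc(OC)c(OC)c3OC)C2=O)cc1[N+](=O)[O-]` gives 1560 nM in this assay. Compound 2 `COc1ccc(/C=C2\Cc3cc(OC)c(OC)c(OC)c3C2=O)cc1O` reaches only the limit of this assay, reported as > 10000 nM. Compound 3 `COc1ccc(/C=C2\Cc3cc(OC)c(OC)c(OC)c3C2=O)cc1[N+](=O)[O-]` likewise reaches only the limit, reported as > 10000 nM. Since both ends sit at a limit, the step that the two limits leave unreadable from compound 2 to compound 3 cannot be read; this is the situation described by the limit of > 10000 nM in this assay, at which 2 of the 3 values shown sit. Compound 3 therefore stands at the weak edge of what this assay can report, while compound 1, which carries the same nitro group on a differently substituted core, gives a measurable number.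

Compound 4 `COc1ccc(/C=C2\Cc3cc(OC)c(OC)c(OC)c3C2=O)cc1` differs from compound 3 in one place: hydrogen in place of nitro on an aromatic carbon, ortho to a methoxy group and meta to a large group. Among the compounds with values here, no measured step shows what removing a nitro group does on this core, so the size and direction of the step in this assay are open. A cautious expectation is that compound 4 stays weak, with the step of an at least 1.2-fold lower number from compound 3 to compound 4 (0.09 log units; that floor lies within the scatter) estimated as small and most likely still near the limit. Compound 4 is thus expected to give about 8000 nM, within a range from 2000 nM to 30000 nM.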

Compound 4, concentration for 50% growth inhibition: > 10000 nM
Compound 4 ended at the assay's limit (the forecaster's own chance of this, stated with the estimate: 50%); at least 1.2-fold (0.09 log units) between middle value and limit.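

In this assay compound 4 gives > 10000 nM, which is a limit and not a number. The steps among compound 2, compound 3 and compound 4 therefore cannot be read: the limit of > 10000 nM in this assay, at which 3 of the 4 values shown sit.

The compounds shown leave open whether hydroxy, nitro or hydrogen at this aromatic carbon makes any difference to growth inhibition on the shared core.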